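An Untested Diethylamino Swap on the Shared Core

A few compounds are considered here, and "the series" means these few. Any claim that something is new, unique, unknown or untested is made for them only; others in the source may bear on it.

Measured compounds:
compound 1, `CC1=C(C(=O)OCC(C)C)C(c2ccoc2)NC(=O)N1`, giving 16% in an assay on membranes from HeLa cells for displacement of a labelled ligand from adenosine receptor A3 (Homo sapiens), read by scintillation counting, with a stated time of 180 min, tested at 1 uM; on this read-out lower numbers stand for less inhibition and higher numbers for more inhibition at the one concentration tested (going by the name of the read-out)
compound 2, `CC1=C(C(=O)CC(C)C)C(c2ccoc2)NC(=O)N1`, giving 18% in this assay

Compound 2 stands at the top of the two numbers shown, yet the only measured step, a number 2 percentage points higher from compound 1 to compound 2 (within the scatter), lies within the scatter, so the two compounds cannot really be told apart on this read-out.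

Compound 3, `CCN(CC)C(=O)C1=C(C)NC(=O)NC1c1ccoc1`, is the next compound, differing from compound 2 by diethylamino in place of isobutyl on a carbonyl carbon. The step from compound 1 to compound 2 bears on it only loosely: it also changed the group on the same carbonyl carbon and gave nothing beyond the scatter. For the measured compounds named here, no measured step exchanges a carbon chain for a nitrogen-bearing group, so there is no direct guide. Compound 3 is therefore expected to show no step beyond the scatter, a number 1 percentage points lower from compound 2 to compound 3 (within the scatter). Compound 3 is estimated at 17%, with a range from 5% to 32%.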

Compound 3, a percentage reported as inhibition, at one concentration (the size of the read-out at that concentration, not a potency): 37%
Compound 3: middle estimate off by 20 percentage points, on the low side; the whole stated range lies below it.
By their numbers in this assay, from the lowest: compounds 1 and 2 (each within the scatter of the next); then compound 3.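

At this position, the carbonyl carbon whose other neighbour is the double-bonded ring carbon, the choice of group can move the read-out: this assay shows a number 19 percentage points higher from compound 2 to compound 3 (beyond the scatter) on going to diethylamino from isobutyl. Diethylamino also stands apart from isobutoxy, with a number 21 percentage points higher from compound 1 to compound 3 (beyond the scatter) in the same read-out, so it is the one group of the three that clears the scatter, and it is also the only one that joins this carbonyl carbon through nitrogen. Nothing available here explains this rise.

With only one nitrogen-linked group shown, it remains open whether the nitrogen or the pair of ethyl chains goes with the higher number. Dimethylamino, a monoethylamino group or a ring amine such as piperidine on the same carbonyl carbon would help separate these two readings.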